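Swapping a hydroxy for an amino on a sulfonamide scaffold

The compounds below may be only part of what the source reports. "The series", "measured", "known", "first", "only" and "open" are said of these compounds alone.

This series was tested in a functional assay on MES-SA cells (Homo sapiens) for cytotoxicity, read by trypan blue exclusion, with a stated time of 96 h; on this read-out higher numbers stand for weaker inhibition of growth and lower numbers for stronger inhibition of growth. Compound 1 `COc1ccc(NS(=O)(=O)/C=C/c2c(OC)cc(OC)cc2OC)cc1` gives 50 nM in this assay. Compound 2 `COc1cc(OC)c(/C=C/S(=O)(=O)Nc2ccc(OC)c(O)c2)c(OC)c1` carries a hydroxy where compound 1 carries hydrogen; in this assay compound 2 gives 25 nM. Going by the values given here, on the numbers so far compound 2 sits at the lower end of the two, but the step of a 2.0-fold lower number from compound 1 to compound 2 (0.30 log units; within the scatter) falls within the scatter, so the two compounds cannot be told apart in this assay.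

Compound 3 `COc1cc(OC)c(/C=C/S(=O)(=O)Nc2ccc(OC)c(N)c2)c(OC)c1` has not yet been measured. It differs from compound 2 in one place: amino in place of hydroxy on an aromatic carbon. The change sits on an aromatic carbon of a six-membered aromatic ring of carbon only, ortho to a methoxy group.

Among the compounds with values here, no measured step exchanges a hydroxy for an amino. Within the data shown here, the only step available, from hydrogen to hydroxy at this same position, stayed within the scatter, so there is no evidence that this position is sensitive to change. The expected step of a 1.2-fold higher number from compound 2 to compound 3 (0.08 log units; within the scatter) is therefore small, with no clear direction. Compound 3 is estimated at 30 nM in this assay, within a range from 10 nM to 100 nM.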

Compound 3, concentration for 50% growth inhibition: 4 nM
Compound 3: middle estimate off by 7.5-fold (0.88 log units), on the high side; the whole stated range lies above it.
By their numbers in this assay, from the lowest: compound 3; then compounds 2 and 1 (each within the scatter of the next).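

The earlier step from hydrogen to hydroxy stayed within the scatter and gave no sign that this aromatic carbon responds to change, but the new result shows that it does. In this assay, exchanging hydroxy for amino gives a step beyond the scatter (a 6.3-fold lower number from compound 2 to compound 3 (0.80 log units; beyond the scatter)), and the comparison with the plain hydrogen compound gives a larger one (a 13-fold lower number from compound 1 to compound 3 (1.10 log units; beyond the scatter)), leaving compound 3 with the strongest inhibition of growth of the three. So the position is not indifferent to what it carries, and the identity of the group matters even though hydroxy and amino differ by a single heavy atom; nothing in the data offers an explanation for the difference between these two groups.

Going by these compounds alone, what remains open is whether amino is special here or only one of several groups that would do as well, which a methylamino or an acetamido group on the same carbon could begin to show. From the compounds shown here alone, it is also open whether the advantage of amino over hydroxy would persist in other cell lines or with a different arrangement of the methoxy groups on the shared core.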